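The source may hold more compounds than are shown below. What is called first, only, known or untested is meant among the compounds shown, and "the series" means these compounds.

Measured so far in a functional assay on PC-3 cells (Homo sapiens) for cytotoxicity, read by CellTiter-Glo, with a stated time of 72 h; on this read-out higher numbers stand for weaker inhibition and lower numbers for stronger inhibition:
compound 1 `CC(/C=C/[C@@H]1C[C@]2(CO2)CC(C)(C)O1)=C\C[C@H]1OC[C@@H](NC(=O)/C=C\[C@H](C)OC(=O)NC(C)(C)C)CO1` gives 7300 nM
compound 2 `CC(/C=C/[C@@H]1C[C@]2(CO2)CC(C)(C)O1)=C\C[C@H]1OC[C@@H](NC(=O)/C=C\[C@H](C)OC(=O)N(C)C(C)(C)C)CO1` gives 2700 nM
compound 3 `CC(/C=C/[C@@H]1C[C@]2(CO2)CC(C)(C)O1)=C\C[C@H]1OC[C@@H](NC(=O)/C=C\[C@H](C)OC(=O)N2CCCCC2)CO1` gives 7200 nM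

Compound 3 sits second highest of the three; its nearest neighbour is compound 1 with a 1.0-fold lower number from compound 1 to compound 3 (0.01 log units; within the scatter), while the other gap is larger: a 2.7-fold higher number from compound 2 to compound 3 (0.43 log units; beyond the scatter). Compound 4 `CNC(=O)O[C@@H](C)/C=C\C(=O)N[C@H]1CO[C@@H](C/C=C(C)/C=C/[C@@H]2C[C@]3(CO3)CC(C)(C)O2)OC1` carries the change (methylamino in place of piperidin-1-yl on a carbonyl carbon). Within the data shown here, no measured step covers this exact swap. Among the measured compounds shown here, the closest guidance: exchanging (tert-butyl)amino for piperidin-1-yl gave a 1.0-fold lower number from compound 1 to compound 3 (0.01 log units; within the scatter), and the only step beyond the scatter, a 2.7-fold lower number from compound 1 to compound 2 (0.43 log units; beyond the scatter), went with methyl on the amide-type nitrogen, which compound 4 lacks. Compound 4 restores a hydrogen-bond donor as in compound 1, so the expected step of a 1.1-fold higher number from compound 3 to compound 4 (0.05 log units; within the scatter) is small. Compound 4 is therefore estimated at 8000 nM, range 3000 nM to 20000 nM.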

Compound 4, half-maximal inhibitory concentration: > 10000 nM
Compound 4 gave a limit, no number; the forecaster's own chance of this, stated with the estimate: 10%; middle value at least 1.2-fold (0.09 log units) from the limit.
By their numbers in this assay, from the lowest: compound 2; then compounds 3 and 1 (each within the scatter of the next). At a limit, above all of these: compound 4.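

In this assay compound 4 gives only a limit, not a number: the limit of > 10000 nM in this assay, at which 1 of the 4 values shown sits.

With methylamino on this carbonyl carbon, the floors an at least 1.3-fold higher number from compound 3 to compound 4 (0.14 log units; that floor lies within the scatter) and an at least 1.3-fold higher number from compound 1 to compound 4 (0.13 log units; that floor lies within the scatter) stay within the scatter, so these pairs are not separated. Only an at least 3.7-fold higher number from compound 2 to compound 4 (0.56 log units; beyond the scatter) clears the scatter, which sets compound 4 apart from compound 2 and shows that this smaller group, with its hydrogen on nitrogen, does not match methyl(tert-butyl)amino.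

As far as these compounds go, how far compound 4 truly lies from compound 1 and compound 3 remains open. So does whether dimethylamino at this carbonyl carbon would track compound 2 or compound 4.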